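Removing the Chloro Group from Compound 1

A few compounds are considered here, and "the series" means these few. Any claim that something is new, unique, unknown or untested is made for them only; others in the source may bear on it.

Measured so far in a functional assay on PC-3 cells (Homo sapiens) for inhibition, read by sulforhodamine B assay, with a stated time of 48 h; on this read-out lower numbers stand for stronger inhibition and higher numbers for weaker inhibition:
compound 1 `O=c1c(C(=S)Nc2ccccc2)coc2cc(Cl)ccc12`: 90800 nM
compound 2 `O=c1c(C(=S)Nc2ccccc2)coc2cc(Cl)c(Cl)cc12`: 95400 nM
compound 3 `O=c1c(C2N=C(c3ccccc3)SS2)coc2cc(Cl)ccc12`: 38400 nM

Among these three numbers compound 1 stands second highest. Compound 2 sits nearest to it, and the two lie within the scatter of each other, so no order between them can be read. Compound 3 lies furthest from compound 1, with a lower number that goes beyond the scatter.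

Compound 4 `O=c1c(C(=S)Nc2ccccc2)coc2ccccc12` differs from compound 1 by hydrogen in place of chloro on an aromatic carbon. Among the measured compounds shown here, the one measured step that bears on this change is the step of a 1.1-fold higher number from compound 1 to compound 2 (0.02 log units; within the scatter), in which a chloro group entered on an aromatic carbon rather than left; that step stayed within the scatter. Compound 3 differs from compound 1 at another place and says nothing about this step. On this basis no step beyond the scatter in this assay is expected for the change from compound 1 to compound 4, that is a 1.0-fold lower number from compound 1 to compound 4 (0.00 log units; within the scatter). Compound 4 is accordingly estimated at 90000 nM, with a range from 40000 nM to 200000 nM.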

Compound 4, half-maximal inhibitory concentration: 60600 nM
Compound 4: the middle estimate sits 1.5-fold (0.17 log units) above what was measured; measured number inside the range.
By their numbers in this assay, from the lowest: compounds 3, 4, 1 and 2 (each within the scatter of the next, the first and the last beyond it).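

In this assay the earlier compounds had shown only a chloro group entering, and the new step, a 1.5-fold lower number from compound 1 to compound 4 (0.18 log units; within the scatter), is the first to show the chloro group of compound 1 leaving the core. This step also stays within the scatter, so the read-out does not separate chloro from hydrogen on this aromatic carbon, and no order can be drawn between the two. No measurement at hand gives a reason for this result.

The compounds shown leave open whether another group on this carbon, such as an amine, a methoxy group or a carboxylic acid, would move the number beyond the scatter. They also leave open whether hydrogen in place of chloro on compound 3 would stay within the scatter too.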